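This account rests on a few compounds, and the source may have more. Where it says the series, first, only, none or still open, it means among the compounds named here.

Measured so far:
compound 1, `COC(=O)CN(C)c1nc(Nc2ccccc2)ncc1[N+](=O)[O-]` — > 100000 nM
compound 2, `CCOC(=O)CN(Cc1ccccc1)c1nc(NCc2cccc(OC)c2)ncc1[N+](=O)[O-]` — 80700 nM
compound 3, `COC(=O)CN(C)c1nc(Nc2cc(OC)c(OC)c(OC)c2)ncc1[N+](=O)[O-]` — 25900 nM

In a functional assay on MDA-MB-231 cells (Homo sapiens) for antiproliferative activity, read by MTT assay, with a stated time of 48 h (a lower number here means a stronger inhibitor, a higher number a weaker inhibitor), compound 1 gives > 100000 nM, which is a limit of the assay and not a number (the limit of > 100000 nM in this assay, at which 1 of the 3 values shown sits). Of the two numbers in this assay, compound 2 with 80700 nM stands highest; compound 3 with 25900 nM sits lower by a gap beyond the usual scatter. Within the data shown here, no two measured compounds differ in one place only, so no measured step is available to lean on.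

Compound 4, `CCOC(=O)CN(Cc1ccccc1)c1nc(Nc2cccc(OC)c2)ncc1[N+](=O)[O-]`, is the next member and has not yet been measured in this assay. Relative to compound 2 the change is 3-methoxyphenyl in place of 3-methoxybenzyl on a nitrogen on an aromatic ring. The measured compounds that carry an aryl group on that nitrogen, compound 1 at its limit and compound 3 at its number, do not point in one direction together, so the change is read as likely to move the number only modestly, if at all. The step from compound 2 to compound 4 in this assay is expected to be a 1.8-fold lower number from compound 2 to compound 4 (0.25 log units; within the scatter), a small improvement near the edge of the scatter. Compound 4 is therefore estimated at 45000 nM in this assay, with a range from 10000 nM to 150000 nM.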

Compound 4, half-maximal inhibitory concentration: 47200 nM
The estimate for compound 4 lay 1.0-fold (0.02 log units) below the measured number; low and high end bracket the measured number.
By their numbers in this assay, from the lowest: compounds 3, 4 and 2 (each within the scatter of the next, the first and the last beyond it). At a limit, above all of these: compound 1.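

Among these compounds, the first step in this assay that can be read in one place is a 1.7-fold lower number from compound 2 to compound 4 (0.23 log units; within the scatter), with 3-methoxyphenyl in place of 3-methoxybenzyl on a nitrogen on an aromatic ring. Among the compounds shown here, for this pair, (3-methoxybenzyl)amino and (3-methoxyphenyl)amino therefore cannot be told apart in this assay, which the earlier compounds could not show because no two of them differed in one place only. The finding is confined to this one pair, in which the ester and the benzyl group on the other nitrogen stay the same.

From the compounds shown here alone, compound 3 differs from compound 4 in more than one place, so the groups behind its number remain unassigned, and it remains open how a longer chain in place of 3-methoxybenzyl, or a carboxylic acid or an amine in place of the ester, would read. Compound 1 remains a limit and not a number, and it supplies no step size: the limit of > 100000 nM in this assay, at which 1 of the 4 values shown sits.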